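Thiocarbamate in place of carbamate on the piperidine

This account rests on a few compounds, and the source may have more. Where it says the series, first, only, none or still open, it means among the compounds named here.

The series is followed in a functional assay on CHO-K1 cells with Glucose-dependent insulinotropic receptor (Homo sapiens) as the target, read by a luciferase reporter, with a stated time of 5 h; a lower number here means a smaller maximal response, a higher number a larger maximal response. Compound 1 `CC(C)(C)OC(=O)N1CCC(Oc2cccc3c2CCN3c2ccc(S(C)(=O)=O)cc2)CC1` gives 92% in this assay. Compound 2 `CC(C)OC(=O)N1CCC(Oc2ncnc3c2CCN3c2ccc(-c3nccs3)cc2F)CC1` gives 74% in this assay. Compound 3 `COC(=O)N1CCC(Oc2ncnc3c2CCN3c2ccc(S(C)(=O)=O)cc2F)CC1` gives 119% in this assay, the highest of the three numbers; the gap to compound 1 and the larger gap to compound 2 both lie beyond the usual scatter.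

Compound 4 `CCSC(=O)N1CCC(Oc2ncnc3c2CCN3c2ccc(S(C)(=O)=O)cc2F)CC1` differs from compound 3 in one place: ethylsulfanyl in place of methoxy on a carbonyl carbon. Among the measured compounds shown here, no measured pair in this set changes the same position, so the size of this step cannot be read from a comparison on hand. The account therefore expects a step of modest size in this assay, if anything a small drop, and most likely one that does not clearly exceed the scatter.

On that basis compound 4 is expected to give about 108% in this assay, between 82% and 132%, an expected step of a number 11 percentage points lower from compound 3 to compound 4 (beyond the scatter).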

Compound 4, largest response reached (reported as percent of maximum), in percent of the reference or control that the assay uses: 128%
Compound 4: the middle estimate sits 20 percentage points below what was measured, and the stated range covers the measured number.
By their numbers in this assay, from the lowest: compound 2; then compound 1; then compounds 3 and 4 (each within the scatter of the next).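

Among the compounds shown here, this is the first step in the set that can be read at this position: in this assay, ethylsulfanyl in place of methoxy on the carbonyl carbon gives a number 9 percentage points higher from compound 3 to compound 4 (within the scatter). The maximal response of compound 3 is therefore kept when the group on this carbonyl carbon changes both its linking atom and its chain, so this position accepts at least this one exchange without a change beyond the scatter. Nothing on hand accounts for this result.

Since the step changes oxygen to sulfur and methyl to ethyl together, the compounds shown cannot separate the two; ethoxy or methylsulfanyl on the same carbonyl carbon would do so. They also leave open whether a longer chain on the sulfur, or an amine in its place, would keep the response.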